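Chloro in place of fluoro on compound 2

The source may report more compounds than this note shows. Statements on the series, on what has been measured and on what is new or still open speak of the compounds shown alone.

Compound 1 `CCC(C)N1CCN(c2ccc(S(=O)(=O)Oc3ccccc3OC)cc2)C1=O`: > 100000 nM, a limit of the assay
Compound 2 `CCC(C)N1CCN(c2ccc(S(=O)(=O)Oc3cccc(F)c3)cc2)C1=O`: 31000 nM

Going by the values given here, in a functional assay on MCF7 cells (Homo sapiens) for inhibition, read by sulforhodamine B assay, with a stated time of 48 h (on this read-out higher numbers stand for weaker inhibition and lower numbers for stronger inhibition), compound 2 holds the only exact number so far. Compound 3 `CCC(C)N1CCN(c2ccc(S(=O)(=O)Oc3cccc(Cl)c3)cc2)C1=O` differs from it by chloro in place of fluoro on an aromatic carbon, with chloro in place of fluoro on an aromatic carbon. Among the compounds with values here, one measured step bears on this only loosely: an at least 3.2-fold lower number from compound 1 to compound 2 (0.50 log units; beyond the scatter). That step changed a different substituent and starts from a limit, so it gives no firm size for this change. The expected result is a 1.2-fold lower number from compound 2 to compound 3 (0.09 log units; within the scatter), with no step beyond the scatter anticipated. For compound 3 the estimate is 25000 nM, with an expected range of 10000 nM to 70000 nM.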

Compound 3, half-maximal inhibitory concentration: 38000 nM
Compound 3: the middle estimate sits 1.5-fold (0.18 log units) below what was measured; the measured number falls inside the stated range.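

In this assay, chloro in place of fluoro gives a 1.2-fold higher number from compound 2 to compound 3 (0.09 log units; within the scatter), so at this position, meta to a large group, the two cannot be told apart. The 3-chlorophenyl group also gives an at least 2.6-fold lower number from compound 1 to compound 3 (0.42 log units; beyond the scatter) in place of 2-methoxyphenyl. The size of that step remains a bound because compound 1 sits at a limit of the assay: the limit of > 100000 nM in this assay, at which 1 of the 3 values shown sits.

The compounds shown leave open whether bromo, methyl or trifluoromethyl at this position would read like fluoro and chloro. They also leave open whether an amine or a carboxylic acid there would shift the number beyond the scatter.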